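Pyridin-2-yl in Place of the Pyrazolyl Group

This account rests on a few compounds, and the source may have more. Where it says the series, first, only, none or still open, it means among the compounds named here.

Compound 2 `Cc1nn(-c2ccccc2)cc1/C=N/Nc1nc(Nc2ccccc2)nc(Nc2ccc(S(N)(=O)=O)cc2)n1` gives 5300 nM in a functional assay on SK-MEL-5 cells (Homo sapiens) for inhibition, read by sulforhodamine B assay, with a stated time of 48 h (on this read-out higher numbers stand for lower toxicity in this test and lower numbers for higher toxicity in this test), and it sits alongside compound 1 `NS(=O)(=O)c1ccc(Nc2nc(N/N=C/c3ccc(C(F)(F)F)cc3)nc(Nc3ccccc3)n2)cc1`, which gives 5820 nM; the step of a 1.1-fold lower number from compound 1 to compound 2 (0.04 log units; within the scatter) lies within the scatter. Compound 3 `NS(=O)(=O)c1ccc(Nc2nc(N/N=C/c3ccccn3)nc(Nc3ccccc3)n2)cc1` carries a different group at the same place: pyridin-2-yl in place of 3-methyl-1-phenyl-1H-pyrazol-4-yl on a carbon with a double bond to nitrogen. Among the compounds with values here, the only measured step that bears on this change, a 1.1-fold lower number from compound 1 to compound 2 (0.04 log units; within the scatter), also replaced the group on this carbon with a double bond to nitrogen and produced no shift beyond the scatter, so for compound 3 no step beyond the scatter is expected, a 1.0-fold higher number from compound 2 to compound 3 (0.02 log units; within the scatter). Compound 3 is therefore estimated at 5500 nM, within 2000 nM to 15000 nM.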

Compound 3, concentration lethal to 50% of the cells: 4710 nM
The estimate for compound 3 lay 1.2-fold (0.07 log units) above the measured number, within the range that was stated.
By their numbers in this assay, from the lowest: compounds 3, 2 and 1 (each within the scatter of the next).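

Pyridin-2-yl, a single ring, brings a 1.1-fold lower number from compound 2 to compound 3 (0.05 log units; within the scatter) when it replaces the two-ring 3-methyl-1-phenyl-1H-pyrazol-4-yl, and a 1.2-fold lower number from compound 1 to compound 3 (0.09 log units; within the scatter) when it replaces 4-(trifluoromethyl)phenyl. On this carbon with a double bond to nitrogen, a smaller group with a ring nitrogen therefore leaves the number in this assay within the scatter of both earlier compounds. No measurement on hand accounts for this closeness.

Still open, as far as these compounds go, is whether a group without an aromatic ring, such as an amine, a carboxylic acid or a longer alkyl chain, would move the number beyond the scatter at this place.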